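Chlorophenyl to Bromophenyl on the Amine: an Unreadable Step

This account rests on a few compounds, and the source may have more. Where it says the series, first, only, none or still open, it means among the compounds named here.

Compound 1 `Fc1ccc(Nc2nc(-c3cccc(F)c3)nc3ccc(F)cc23)cc1` in a functional assay on MDA-MB-231 cells (Homo sapiens) for cytotoxicity, read by MTT assay, with a stated time of 48 h (a higher number here means a weaker inhibitor, a lower number a stronger inhibitor), gives > 50000 nM, which is a limit of the assay and not a number.
Compound 2 `Fc1cccc(-c2nc(Nc3ccccc3Cl)c3cc(F)ccc3n2)c1` in this assay gives > 50000 nM, again a limit rather than a number.

Compound 2 therefore stands only at a limit; both values shown sit at the limit of > 50000 nM in this assay, at which 2 of the 2 values shown sit. The change to compound 3 `Fc1cccc(-c2nc(Nc3cccc(Br)c3)c3cc(F)ccc3n2)c1` is 3-bromophenyl in place of 2-chlorophenyl on a nitrogen on an aromatic ring. Going by the values given here, the only measured step, a step that the two limits leave unreadable from compound 1 to compound 2, is itself unreadable, so it gives no size, in either direction, to expect in this assay. Compound 3 is thus expected to stay at the limit, with an estimated 80000 nM (range 20000 nM to 300000 nM), the expected step that the limit leaves unreadable from compound 2 to compound 3 being no more than scatter.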

Compound 3, half-maximal inhibitory concentration: > 50000 nM
Compound 3 was reported as a limit; the forecaster's own chance of this, stated with the estimate: 80%; the middle value lies beyond the limit too.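

No step among compound 1, compound 2 and compound 3 can be read in this assay, since each gives only a limit and not a number: the limit of > 50000 nM in this assay, at which 3 of the 3 values shown sit.

The compounds shown leave open how strong each one really is, and whether changing the phenyl group on the nitrogen alters cytotoxicity.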